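From a dichlorobenzyl to a methoxybenzyl amine

This account rests on a few compounds, and the source may have more. Where it says the series, first, only, none or still open, it means among the compounds named here.

Compound 1 `Nc1cc(N)c2nc(-c3ccccc3)c(NCc3ccc(Cl)c(Cl)c3)nc2c1` is the reference point of this account. In a functional assay on IGROV-1 cells (Homo sapiens) for inhibition, read by sulforhodamine B assay, with a stated time of 48 h (a lower number here means a stronger inhibitor of growth, a higher number a weaker inhibitor of growth), compound 1 gives 5890 nM, the lowest of the three numbers in hand, and since the other two values both lie beyond the usual scatter from it, compound 1 is the strongest growth inhibitor of the set. Compound 2 `Nc1cc(N)c2nc(-c3ccccc3)c(Sc3ccc(Cl)c(Cl)c3)nc2c1` gives 27500 nM in this assay, and compound 3 `CCOC(=O)[C@H](CCC(=O)O)NC(=O)c1ccc(Oc2nc3cc(N)cc(N)c3nc2-c2ccccc2)cc1` gives 79400 nM. Neither compound 2 nor compound 3 differs from compound 1 in a single place, so the three measured values offer no isolated one-change comparison to lean on.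

Compound 4 `COc1ccc(CNc2nc3cc(N)cc(N)c3nc2-c2ccccc2)cc1` has not been measured. It differs from compound 1 as follows: 4-methoxyphenyl in place of 3,4-dichlorophenyl on a saturated chain carbon bound to a nitrogen on an aromatic ring. Among the measured compounds shown here, with no single-change step available among the measured compounds, the direction of this exchange must be guessed from compound 1 alone, whose value of 5890 nM sets the starting point. The author expects a modest rise in the number, with the step from compound 1 to compound 4 estimated at a 1.9-fold higher number from compound 1 to compound 4 (0.27 log units; within the scatter), close to the edge of the scatter. Compound 4 is therefore estimated to give 11000 nM in this assay, with a range from 3500 nM to 40000 nM.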

Compound 4, concentration for total growth inhibition: 26900 nM
Compound 4: middle estimate off by 2.4-fold (0.39 log units), on the low side, within the range that was stated.
By their numbers in this assay, from the lowest: compound 1; then compounds 4 and 2 (each within the scatter of the next); then compound 3.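

In this assay, the exchange of 3,4-dichlorophenyl for 4-methoxyphenyl gives the first single-change comparison in this set, a 4.6-fold higher number from compound 1 to compound 4 (0.66 log units; beyond the scatter), so this place on a saturated chain carbon bound to a nitrogen on an aromatic ring is shown to respond to what the aromatic ring carries. The leaving and entering groups have the same number of heavy atoms and the same kind of six-membered aromatic ring, so the step goes with a change in the ring's substituents, with both chlorine atoms gone and a methoxy group in their place, and not with a change in heavy-atom count. No measurement shown here accounts for the size or direction of this step.

Since this one exchange removes the chlorines and adds the methoxy group together, the compounds shown leave open how much of the step belongs to each. A plain phenyl or a phenyl carrying a single chlorine at this place would separate the two, and a longer chain between the nitrogen and the ring would test whether the chain length matters as well.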